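This account rests on a few compounds, and the source may have more. Where it says the series, first, only, none or still open, it means among the compounds named here.

Measured so far in a functional assay on HeLa cells (Homo sapiens) for antiproliferative activity, read by CCK-8 assay, with a stated time of 72 h, tested at 2 uM; on this read-out higher numbers stand for a stronger effect at the one concentration tested and lower numbers for a weaker effect:
compound 1 `CN(C(=S)SCc1ccc(C(=O)Nc2ccccc2N)cc1)c1cccnc1` gives 16%;
compound 2 `Nc1ccccc1NC(=O)c1ccc(CSC(=S)N2CCN(Cc3ccncc3)CC2)cc1` gives 59.5%;
compound 3 `Nc1ccccc1NC(=O)c1ccc(CSC(=S)N2CCc3cc([N+](=O)[O-])ccc32)cc1` gives 32.6%.

Compound 2 stands highest of the three numbers in this assay. Nearest to it is compound 3, lower by a gap beyond the scatter; furthest is compound 1, lower by a larger gap, also beyond the scatter. Within the data shown here, no two measured compounds differ in one place only, so no single-point step is known from the data.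

Compound 4 `Nc1ccccc1NC(=O)c1ccc(CSC(=S)N2CCN(c3cnccn3)CC2)cc1` is not yet measured. It differs from compound 2 as follows: pyrazin-2-yl in place of (pyridin-4-yl)methyl on an amine nitrogen in a ring. The spread across the three measured compounds shows that changes around the amine nitrogen can move the number beyond the scatter, but none of them tracks this particular change. A downward step a number 14.5 percentage points lower from compound 2 to compound 4 (beyond the scatter) in this assay is expected, possibly beyond the scatter. For compound 4 the estimated value in this assay is 45%, with an expected range from 25% to 65%.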

Compound 4, a percentage reported as inhibition, at one concentration (the size of the read-out at that concentration, not a potency): 70.4%
Compound 4: the middle estimate sits 25.4 percentage points below what was measured; the measured number lies above the stated range.
By their numbers in this assay, from the lowest: compound 1; then compound 3; then compound 2; then compound 4.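

In this assay, among these compounds, pyrazin-2-yl in place of (pyridin-4-yl)methyl on the amine nitrogen in the ring gives a number 10.9 percentage points higher from compound 2 to compound 4 (beyond the scatter) and is the first single-place step read. It shows that this nitrogen can carry a six-membered aromatic ring with 2 hetero atoms and that the number still rises. Nothing measured here speaks to the origin of this step.

The change swaps the ring and removes the methylene link together, leaving their contributions unseparated. Pyridin-4-yl or (pyrazin-2-yl)methyl on the same nitrogen would tell them apart.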